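Aryl swap on the piperazine of the naphthoquinone core

The source may hold more compounds than are shown below. What is called first, only, known or untested is meant among the compounds shown, and "the series" means these compounds.

Compound 1 `Cc1ccc(N2CCN(C3=CC(=O)c4ccccc4C3=O)CC2)cc1` is the reference point of this short series. In a functional assay on DU-145 cells (Homo sapiens) for inhibition, read by MTT assay, with a stated time of 72 h (on this read-out higher numbers stand for weaker inhibition and lower numbers for stronger inhibition), compound 1 gives 8200 nM, the highest of the two numbers recorded so far. Compound 2 `COc1ccccc1N1CCN(C2=CC(=O)c3ccccc3C2=O)CC1` carries a different aryl on the same amine nitrogen in a ring; in this assay compound 2 gives 8000 nM. Within the data shown here, the one change already measured, a 1.0-fold lower number from compound 1 to compound 2 (0.01 log units; within the scatter), shows that exchanging the aryl on that nitrogen left the read-out unmoved.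

Compound 3 `O=C1C=C(N2CCN(c3ccc(F)c(Cl)c3)CC2)C(=O)c2ccccc21` is the next member and has not yet been measured. The difference from compound 1 is 3-chloro-4-fluorophenyl in place of 4-methylphenyl on an amine nitrogen in a ring. Among the measured compounds shown here, only the step from compound 1 to compound 2 bears on this change, since it too exchanges the aryl on the same ring nitrogen, and that step stayed within the scatter. On that basis no movement beyond the scatter is expected in this assay for compound 3, in either direction. The expected step is a 1.1-fold lower number from compound 1 to compound 3 (0.04 log units; within the scatter). Compound 3 is therefore estimated at 7500 nM, with a range from 3000 nM to 20000 nM.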

Compound 3, half-maximal inhibitory concentration: 32200 nM
The estimate for compound 3 lay 4.3-fold (0.63 log units) below the measured number; the measured number lies above the stated range.
By their numbers in this assay, from the lowest: compounds 2 and 1 (each within the scatter of the next); then compound 3.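

With 3-chloro-4-fluorophenyl on the amine nitrogen in a ring, this assay records a 3.9-fold higher number from compound 1 to compound 3 (0.59 log units; beyond the scatter) and a 4.0-fold higher number from compound 2 to compound 3 (0.60 log units; beyond the scatter) as modest steps toward weaker inhibition, so this position does not tolerate every aryl equally. The flat result from the earlier pair therefore holds only for 4-methylphenyl and 2-methoxyphenyl, and it cannot be extended to the aryl groups at this position in general; compound 3 is the weakest of the three, while compound 1 and compound 2 remain within the scatter of each other. No supporting data are available to explain this shift.

The change brings in chlorine and fluorine together and removes the methyl group at the same time, so the compounds shown leave open whether the shift belongs to one halogen, to the pair, or to the loss of that methyl group. Unsubstituted phenyl, 3-chlorophenyl and 4-fluorophenyl on the same nitrogen would separate these possibilities, while a benzyl group would test whether an aryl attached directly to that nitrogen matters at all.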